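Lengthening the chloroalkyl amide chain on compound 2

This account rests on a few compounds, and the source may have more. Where it says the series, first, only, none or still open, it means among the compounds named here.

For the measured compounds named here, compound 2 `CC(C)c1ccccc1OS(=O)(=O)c1ccc(NC(=O)CCl)cc1` gives 3900 nM in a functional assay on M21 cells (Homo sapiens) for antiproliferative activity, read by sulforhodamine B assay, with a stated time of 48 h (a lower number here means a stronger inhibitor, a higher number a weaker inhibitor), the lower of the two numbers so far, with compound 1 `CCCCCC(=O)Nc1ccc(S(=O)(=O)Oc2ccccc2C(C)C)cc1` at 6700 nM within the scatter of it. Compound 3 `CC(C)c1ccccc1OS(=O)(=O)c1ccc(NC(=O)CCCCl)cc1` carries 2-chloroethyl in place of chloro on a saturated chain carbon bound to a carbonyl carbon. Going by the values given here, the only step known at that carbon, a 1.7-fold lower number from compound 1 to compound 2 (0.24 log units; within the scatter), also changed the chain there and stayed within the scatter. The step from compound 2 to compound 3 is therefore expected to be small, a 1.2-fold higher number from compound 2 to compound 3 (0.06 log units; within the scatter), with no clear direction. Compound 3 is estimated at 4500 nM, in the range 1800 nM to 11000 nM.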

Compound 3, half-maximal inhibitory concentration: 5100 nM
Compound 3: the middle estimate sits 1.1-fold (0.05 log units) below what was measured; the measured number falls inside the stated range.
By their numbers in this assay, from the lowest: compounds 2, 3 and 1 (each within the scatter of the next).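

In this assay, 2-chloroethyl in place of chloro on a saturated chain carbon bound to a carbonyl carbon gives a 1.3-fold higher number from compound 2 to compound 3 (0.12 log units; within the scatter) and stays within the scatter. Chloro in place of ethyl, three bonds along the chain from a carbonyl carbon, gives a 1.3-fold lower number from compound 1 to compound 3 (0.12 log units; within the scatter) and also stays within it. Across these three compounds, then, neither the chain change nor the chlorine swap moves the number beyond the scatter, and no supporting data bear on this result. As far as these compounds go, whether an amine, a carboxylic acid or a much longer chain here would move the number beyond the scatter stays open.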